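The source may hold more compounds than are shown below. What is called first, only, known or untested is meant among the compounds shown, and "the series" means these compounds.

Of the compounds shown here, three have been measured in a functional assay on CCRF-CEM cells for antagonist activity at C-X-C chemokine receptor type 4 (Homo sapiens), read by calcium flux, with stated times of 25 min and 90 s; on this read-out higher numbers stand for weaker inhibition and lower numbers for stronger inhibition. Compound 1 `c1ccc2c(c1)CN[C@@H](CN(CCC1CCNCC1)[C@H]1CCCc3cccnc31)C2` gives 150 nM, the highest of the three numbers. Compound 2 `c1cnc2c(c1)CCC[C@@H]2N(CCCN1CCNCC1)Cc1cc2ccccc2cn1` gives 17 nM, and compound 3 `c1cnc2c(c1)CCC[C@@H]2N(CCCN1CCNCC1)Cc1nc2ccccc2[nH]1` gives 45 nM. Compound 1 thus sits furthest from compound 2 and nearest to compound 3, with both gaps beyond the scatter. For the measured compounds named here, the only single-point step among the measured compounds is a 2.6-fold higher number from compound 2 to compound 3 (0.42 log units; beyond the scatter).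

Compound 4 `c1ccc2c(c1)CN[C@@H](CN(CCCCN1CCNCC1)[C@H]1CCCc3cccnc31)C2` differs from compound 1 by 2-(piperazin-1-yl)ethyl in place of piperidin-4-yl on a saturated chain carbon, two bonds along the chain from an amine nitrogen. Going by the values given here, no measured step touches this change; the step from compound 2 to compound 3 concerns the aromatic group on the other side of the amine nitrogen and gives no direct guidance. What the data do show is that compounds 2 and 3, each carrying a piperazin-1-yl group at the end of a saturated chain, give lower numbers than compound 1, though they differ from compound 1 in more than one place. A modest move toward lower numbers is therefore a cautious expectation, grounded only because compound 2 gives 17 nM and compound 3 gives 45 nM. Compound 4 is expected to give about 80 nM, with a range from 30 nM to 250 nM. That expectation corresponds to a 1.9-fold lower number from compound 1 to compound 4 (0.27 log units; within the scatter).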

Compound 4, half-maximal inhibitory concentration: 66 nM
For compound 4 the middle estimate is 1.2-fold (0.08 log units) above the measured one, within the range that was stated.
By their numbers in this assay, from the lowest: compound 2; then compounds 3 and 4 (each within the scatter of the next); then compound 1.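

In this assay, for the compounds shown here, this is the first single-place reading at the saturated chain carbon two bonds along the chain from an amine nitrogen: 2-(piperazin-1-yl)ethyl in place of piperidin-4-yl gives a 2.3-fold lower number from compound 1 to compound 4 (0.36 log units; beyond the scatter). Going by these compounds alone, the earlier step compared only isoquinolin-3-yl with 1H-benzimidazol-2-yl, so this result is the first to show that the group at the end of this chain can shift the number by a modest amount beyond the scatter, and in the direction of stronger inhibition. The change swaps the ring and lengthens the chain in a single step, and nothing among the data offers an explanation for the shift.

The compounds shown leave open how much of the step belongs to the longer chain and how much to the piperazine ring, a question that a 2-(piperidin-4-yl)ethyl group in the same place would separate. They also leave open whether a 2-(morpholin-4-yl)ethyl group, or a methyl group on the far nitrogen of the piperazine, would keep the number reached by compound 4.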